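Adding Bromo to a Compound at the Assay Limit

A few compounds are considered here, and "the series" means these few. Any claim that something is new, unique, unknown or untested is made for them only; others in the source may bear on it.

In a toxicity assay on THP-1 cells (Homo sapiens) for inhibition (on this read-out lower numbers stand for higher toxicity in this test and higher numbers for lower toxicity in this test), compound 1 `Cn1c(-c2ccccc2)cnc1NC(=O)c1ccccc1` gives > 100000 nM as its reading, which is a limit and not a number. Compound 2 `Cn1c(-c2ccc([N+](=O)[O-])cc2)cnc1NC(=O)c1ccc(F)cc1` gives > 50000 nM as its reading, and this is also a limit. Compound 3 `COc1ccc(-c2cnc(NC(=O)c3ccccc3)n2C)cc1` gives > 100000 nM as its reading, again a limit. Compound 1 therefore has no exact place among the three: the record holds only the limit of > 100000 nM in this assay, at which 2 of the 3 values shown sit, and the limit of > 50000 nM in this assay, at which 1 of the 3 values shown sits, and no measured number.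

Compound 4 `Cn1c(-c2ccccc2)cnc1NC(=O)c1cccc(Br)c1` is compound 1 with one change, bromo in place of hydrogen on an aromatic carbon of a six-membered aromatic ring of carbon only, meta to a large group (bromo in place of hydrogen on an aromatic carbon). For the measured compounds named here, only one measured step replaces a single hydrogen on an aromatic carbon in this way, with methoxy as the new group. It is a step that the two limits leave unreadable from compound 1 to compound 3 and so gives no size to carry over. With no readable step to go on, no change beyond the usual scatter is expected in this assay and no direction can be argued, so the reading will most likely stay at a limit. The estimated change is a number no higher from compound 1 to compound 4 (the limit leaves the size open) on this expectation. For compound 4 the expected value is 100000 nM with an estimated range from 50000 nM to 200000 nM on repeated measurement.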

Compound 4, half-maximal cytotoxic concentration: > 50000 nM
Compound 4: only a limit was reported (the forecaster's own chance of this, stated with the estimate: 80%); the middle value is on the limit's open side.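

Compound 1 and compound 4 both give limits rather than numbers in this assay, so the step that puts bromo in place of hydrogen cannot be read. Whether bromo or any other change shown alters toxicity in this assay stays open: none of the four compounds has a measured number on this read-out.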